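Cinnamamides on a trimethoxybenzophenone core: step to compound 4

The compounds below may be only part of what the source reports. "The series", "measured", "known", "first", "only" and "open" are said of these compounds alone.

All numbers below come from a functional assay on ME-180 cells (Homo sapiens) for cytotoxicity, read by MTT assay, with a stated time of 72 h; a lower number here means a stronger inhibitor, a higher number a weaker inhibitor.

Compound 1 `COc1ccc(C(=O)c2cc(OC)c(OC)c(OC)c2)cc1NC(=O)/C=C/c1cc(OC)c(OC)c(OC)c1`: 2100 nM
Compound 2 `COc1ccc(C(=O)c2cc(OC)c(OC)c(OC)c2)cc1NC(=O)/C=C/c1ccc(F)cc1`: 300 nM
Compound 3 `COc1cc(C(=O)c2cc(OC)c(OC)c(OC)c2)cc(NC(=O)/C=C/c2cc(OC)c(OC)c(OC)c2)c1OC`: 3900 nM

Compound 3 stands highest of the three numbers; against compound 1 the gap is a 1.9-fold higher number from compound 1 to compound 3 (0.27 log units; within the scatter), so the two are not separated by the scatter, while against compound 2 the gap is wider and counted as beyond it. Compound 4 `COc1ccc(/C=C/C(=O)Nc2cc(C(=O)c3cc(OC)c(OC)c(OC)c3)cc(OC)c2OC)cc1N` is not yet measured. It differs from compound 3 in one place: 3-amino-4-methoxyphenyl in place of 3,4,5-trimethoxyphenyl on a double-bonded chain carbon bound to a double-bonded chain carbon.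

For the measured compounds named here, the only measured step that bears on this change is a 7.0-fold lower number from compound 1 to compound 2 (0.85 log units; beyond the scatter), where the same 3,4,5-trimethoxyphenyl on the double-bonded chain carbon was replaced by a smaller ring and the number dropped. The step from compound 1 to compound 3 concerns a different position and says nothing here. The incoming 3-amino-4-methoxyphenyl is not the 4-fluorophenyl of compound 2, so the step is expected to be smaller, but in the same direction. For compound 4 in this assay a lower number than for compound 3 is expected, a step of about a 3.9-fold lower number from compound 3 to compound 4 (0.59 log units; beyond the scatter), giving an estimated 1000 nM with a range from 300 nM to 4000 nM.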

Compound 4, half-maximal inhibitory concentration: 13900 nM
Estimate against measurement, compound 4: 14-fold (1.14 log units) below; measured number above the stated range.
By their numbers in this assay, from the lowest: compound 2; then compounds 1 and 3 (each within the scatter of the next); then compound 4.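

In this assay, the change on a double-bonded chain carbon bound to a double-bonded chain carbon gives a 3.6-fold higher number from compound 3 to compound 4 (0.55 log units; beyond the scatter), so replacing 3,4,5-trimethoxyphenyl at this place does not by itself lower the number. Set beside a 7.0-fold lower number from compound 1 to compound 2 (0.85 log units; beyond the scatter), the two steps at this place run in opposite directions, each beyond the scatter, which shows that the outcome depends on the incoming group, the core, or both, although the steps start from different cores and share no incoming group. Nothing available here gives a measured reason for the rise with 3-amino-4-methoxyphenyl, and the result is recorded without a cause.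

The compounds shown do not separate the effect of the incoming ring from that of the extra methoxy on the core of compound 3, since neither 4-fluorophenyl on that core nor 3-amino-4-methoxyphenyl on the core of compound 1 appears among them. Going by these compounds, it also stays open whether the amino group or the lost methoxy drives the step, and a 3-hydroxy-4-methoxyphenyl at the same place would help to tell these apart.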